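The source may hold more compounds than are shown below. What is called first, only, known or untested is meant among the compounds shown, and "the series" means these compounds.

compound 1 `N#CCN(Cc1ccccc1)Cc1ccc2ccccc2c1` — 0%
compound 2 `O=C(CN(Cc1ccccc1)Cc1ccc2ccccc2c1)OCCO` — 0%

In an assay on HEK293 cells for binding affinity to Substance-K receptor (Rattus norvegicus), read by FRET, tested at 10 uM (on this read-out higher numbers stand for more inhibition at the one concentration tested (going by the name of the read-out) and lower numbers for less inhibition), compound 1 gives 0% and compound 2 gives 0%. Among the measured compounds shown here, both sit at the floor of the scale, and the one measured step, no change at the digits printed from compound 1 to compound 2 (within the scatter), shows that putting (2-hydroxyethoxy)carbonyl in place of cyano on a saturated chain carbon bound to an amine nitrogen moved nothing. Compound 2 therefore stands level with compound 1, with no room to go lower.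

Compound 3 `O=C(CN(Cc1ccccc1)Cc1ccc2ccccc2c1)N1CCCCC1` differs from compound 2 by piperidin-1-yl in place of 2-hydroxyethoxy on a carbonyl carbon. For the measured compounds named here, the earlier step touches the same arm of the shared core, so it is the only guide here, and it was flat. On that basis the step to compound 3 is expected to be small or absent, a number 5 percentage points higher from compound 2 to compound 3 (within the scatter), with any movement only upward from the floor. Compound 3 is estimated at 5%, within a range of -8% to 25%.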

Compound 3, a percentage reported as inhibition, at one concentration (the size of the read-out at that concentration, not a potency): 0%
Compound 3: the middle estimate sits 5 percentage points above what was measured, within the range that was stated.
By their numbers in this assay, from the lowest: compounds 1, 2 and 3 (each within the scatter of the next).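

With piperidin-1-yl in place of 2-hydroxyethoxy on a carbonyl carbon, this assay shows no change at the digits printed from compound 2 to compound 3 (within the scatter), so a group holding a six-membered non-aromatic ring reads the same here as the open chain did. Set against the nitrile, (piperidin-1-yl)carbonyl in place of cyano on a saturated chain carbon bound to an amine nitrogen gives no change at the digits printed from compound 1 to compound 3 (within the scatter), which makes three different groups at this place with the same floor reading. No data are available that would account for this flat result.

From the compounds shown here alone, a reading at the floor cannot separate these groups from one another, so it remains open whether any group at this place can lift the number at all. A carboxylic acid, or an amide carrying a longer chain that ends in an amine, could still read differently here.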